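The source may report more compounds than this note shows. Statements on the series, on what has been measured and on what is new or still open speak of the compounds shown alone.

Compound 3 `C=C1C(=O)[C@]23C[C@@]1(O)CC[C@H]2c1ccc(OS(=O)(=O)c2ccc(C)cc2)c(C)c1[C@@H]3Cn1cc(-c2ccc(OC)cc2)nn1` and compound 1 `C=C1C(=O)[C@]23C[C@@]1(O)CC[C@H]2c1ccc(OS(=O)(=O)c2ccc(C)cc2)c(C)c1[C@@H]3Cn1cc(-c2ccc(C)cc2)nn1` share one core, and in a functional assay on SW480 cells (Homo sapiens) for cytotoxicity, read by MTT assay, with a stated time of 4 days (a lower number here means a stronger inhibitor, a higher number a weaker inhibitor), compound 3 gives 1640 nM. Compound 1, in this assay, gives 1460 nM. For the measured compounds named here, the one change between them, (methyl in place of methoxy on an aromatic carbon), gives a 1.1-fold lower number from compound 3 to compound 1 (0.05 log units; within the scatter). Compound 2 `C=C1C[C@]23C[C@@]1(O)CC[C@H]2c1ccc(O)c(C)c1[C@@H]3Cn1cc(-c2ccc(OC)cc2)nn1` carries a different core, and the difference between the two cores is not broken down here. In this assay compound 2 reaches only a limit, > 20000 nM, with the limit of > 20000 nM in this assay, at which 1 of the 3 values shown sits, marking where it sits. Compound 4 `C=C1C[C@]23C[C@@]1(O)CC[C@H]2c1ccc(O)c(C)c1[C@@H]3Cn1cc(-c2ccc(C)cc2)nn1` arises from compound 2 by the same change, (methyl in place of methoxy on an aromatic carbon). Compound 4 is estimated to give 25000 nM in this assay, because a 1.1-fold lower number from compound 3 to compound 1 (0.05 log units; within the scatter) was within the scatter and compound 2 showed only the limit > 20000 nM. That expectation means the step that the limit leaves unreadable from compound 2 to compound 4.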

Compound 4, half-maximal inhibitory concentration: > 20000 nM
Compound 4: a limit, no number; the forecaster's own chance of this, stated with the estimate: 75%; the middle value lies beyond the limit too.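

For the compounds shown here, compound 2 and compound 4 both stop at a limit in this assay, so no step between them can be read. The compounds shown leave open whether 4-methoxyphenyl to 4-methylphenyl shifts the value at all on this core.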